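A few compounds are considered here, and "the series" means these few. Any claim that something is new, unique, unknown or untested is made for them only; others in the source may bear on it.

Measured compounds:
Compound 1 `CC(C)(C)OC(=O)N1CCC(Oc2cc(Oc3ccc(/C=C4\SC(=O)NC4=O)cc3)ncn2)CC1`: 130 nM
Compound 2 `CCOC(=O)N1CCC(Oc2cc(Oc3cccc(/C=C4\SC(=O)NC4=O)c3)ncn2)CC1`: 819 nM

In a functional assay on CHO-K1 cells for agonist activity at Glucose-dependent insulinotropic receptor (Homo sapiens), read by cAMP accumulation and immunoassay, with a stated time of 1 h (a lower number here means that less compound is needed, a higher number that more compound is needed for the effect), compound 1 gives 130 nM, and compound 2 gives 819 nM, the higher of the two numbers; compound 1 and compound 2 differ in more than one place, so the two values are simply set side by side here. Compound 3 `CC(C)COC(=O)N1CCC(Oc2cc(Oc3cccc(/C=C4\SC(=O)NC4=O)c3)ncn2)CC1` is not yet measured. It differs from compound 2 in one place: isopropyl in place of methyl on a saturated chain carbon bound to an oxygen next to a carbonyl group. For the measured compounds named here, no measured pair shows what a change of this kind does in this assay, so no step size can be read off. The expectation for compound 3 is a small step downward from compound 2, by an amount that may not exceed the scatter: the estimated step from compound 2 to compound 3 is a 1.4-fold lower number from compound 2 to compound 3 (0.14 log units; within the scatter). Compound 3 is therefore estimated at 600 nM, with a range from 200 nM to 2000 nM.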

Compound 3, half-maximal effective concentration: 720 nM
Beside the measured number, compound 3's estimate is 1.2-fold (0.08 log units) below it; measured number inside the range.
By their numbers in this assay, from the lowest: compound 1; then compounds 3 and 2 (each within the scatter of the next).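

For the compounds shown here, compound 2 and compound 3 form the first pair here that differs in one place, and so the first direct reading of this position. In this assay, isopropyl in place of methyl on a saturated chain carbon bound to an oxygen next to a carbonyl group gives a step that stays within the scatter (a 1.1-fold lower number from compound 2 to compound 3 (0.06 log units; within the scatter)). Ethoxycarbonyl and isobutoxycarbonyl therefore cannot be told apart on this core, and nothing at hand bears on why the two values stand so close.

Steps from compound 1 to the other two cannot be read, as it differs from each in more than one place. As far as these compounds go, whether a longer chain, a cyclohexyl ring or a terminal amine at this position would move the number beyond the scatter remains open.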